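The source may report more compounds than this note shows. Statements on the series, on what has been measured and on what is new or still open speak of the compounds shown alone.

Of the compounds shown here, two have been measured so far. Compound 1 `O=C(Nc1cccc(CNc2ncnc3ccccc23)c1)Nc1ccccc1F` carries a fluorine on the outer phenyl of its urea and no substituents on the shared core; in a functional assay on HepG2 cells (Homo sapiens) for antiproliferative activity, read by MTT assay (on this read-out higher numbers stand for weaker inhibition and lower numbers for stronger inhibition), compound 1 gives 17500 nM. Compound 2 `COc1ccccc1NC(=O)Nc1cccc(CNc2ncnc3cc(OC)c(OC)cc23)c1` adds two methoxy groups to the core and replaces the fluorine with a methoxy on the urea phenyl; in this assay compound 2 gives 27200 nM. The two numbers sit within the usual scatter of each other, so neither compound can be called the more or less active on this evidence, and both act only at high concentration.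

Compound 3 `COc1cc2ncnc(NCc3cccc(NC(=O)Nc4ccccc4Cl)c3)c2cc1OC` keeps the dimethoxy core of compound 2 and differs from it in one place: chloro in place of methoxy on an aromatic carbon. Among the measured compounds shown here, no measured pair in this set shows what such a swap does here, so the expectation rests on the closeness of compound 1 and compound 2 alone. The change from compound 2 to compound 3 is expected to stay within the scatter, a 1.4-fold lower number from compound 2 to compound 3 (0.13 log units; within the scatter). Compound 3 is therefore estimated at 20000 nM, with a range from 7000 nM to 60000 nM.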

Compound 3, half-maximal inhibitory concentration: 25500 nM
Compound 3: the middle estimate sits 1.3-fold (0.11 log units) below what was measured, and the stated range covers the measured number.
By their numbers in this assay, from the lowest: compounds 1, 3 and 2 (each within the scatter of the next).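

In this assay, among the compounds shown here, the swap of chloro for methoxy on the outer phenyl of the urea gives a 1.1-fold lower number from compound 2 to compound 3 (0.03 log units; within the scatter), and this is the only comparison so far in which the two compounds differ in just one place. This aromatic carbon, ortho to a large group, can therefore carry either a methoxy, with two heavy atoms and one hydrogen-bond acceptor, or a chloro, with one heavy atom and no acceptor, and the read-out does not tell the two apart. Nothing measured alongside these values offers an explanation for this result.

As far as these compounds go, only these two groups can be compared directly at this position, so it remains open whether an amine, a carboxylic acid or a longer chain such as ethoxy would also leave the number within the scatter or move it clearly. No pair shown differs in the core alone, which leaves open what the two methoxy groups on the core of compound 2 and compound 3 contribute.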